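The source may report more compounds than this note shows. Statements on the series, on what has been measured and on what is new or still open speak of the compounds shown alone.

Working notes on the series.

Compound 3 `COC(=O)Nc1cccc2c1CCCC2c1c[nH]cn1` is the reference point for this step. For the measured compounds named here, in an assay on isolated protein (Cricetulus griseus) for binding affinity to Alpha-1B adrenergic receptor (Mesocricetus auratus), read by radioligand binding (on this read-out lower numbers stand for stronger inhibition and higher numbers for weaker inhibition), compound 3 gives 10000 nM, which is the only outright number in the set. For compound 1 `CCCS(=O)(=O)Nc1cccc2c1CCCC2c1c[nH]cn1` the result in this assay is a limit, < 10000 nM. For compound 2 `CS(=O)(=O)Nc1cccc2c1OCCC2c1c[nH]cn1` the result in this assay is likewise a limit, < 10000 nM. Going by the values given here, the one measured step that reaches compound 3 is a number no lower from compound 1 to compound 3 (the limit leaves the size open), and its size cannot be read, since the limit of < 10000 nM in this assay, at which 2 of the 3 values shown sit, marks where compound 1 sits.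

Compound 4 `CN(c1cccc2c1CCCC2c1c[nH]cn1)S(C)(=O)=O` differs from compound 3 in one place: methyl(methylsulfonyl)amino in place of (methoxycarbonyl)amino on an aromatic carbon. Among the compounds with values here, no measured step exchanges a (methoxycarbonyl)amino for a methyl(methylsulfonyl)amino, so the direction of this change in this assay cannot be taken from a pair in hand. Compounds 1 and 2, which carry sulfonyl groups on the ring nitrogen, show only limits, and they do not bear on the loss of the hydrogen-bond donor that comes with compound 4.

For compound 4 the step of a 1.7-fold lower number from compound 3 to compound 4 (0.22 log units; within the scatter) is therefore expected to stay near the scatter, with a weak lean toward stronger binding. Compound 4 is estimated at 6000 nM, with a range from 1500 nM to 25000 nM.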

Compound 4, inhibition constant: < 10000 nM
Compound 4 was reported as a limit (the forecaster's own chance of this, stated with the estimate: 50%); the middle value does not contradict the limit.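

On the aromatic carbon, methyl(methylsulfonyl)amino in place of (methoxycarbonyl)amino gives a number no higher from compound 3 to compound 4 (the limit leaves the size open) in this assay, so this exchange, which removes the hydrogen-bond donor of (methoxycarbonyl)amino, does not raise the number at this position. The result for compound 4 is a limit, and it gives direction only, not size. The remaining new step, involving compound 1, cannot be read, and most of the set now rests on a single boundary: the limit of < 10000 nM in this assay, at which 3 of the 4 values shown sit.

As far as these compounds go, what remains open is how far below that limit compound 4 lies, and whether the sulfonyl-bearing compounds differ from one another at all in this assay. Also open, from the compounds shown here alone, is how a free amine or an acetamide on the same aromatic carbon would read, as either would test this position without the sulfonyl group.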